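The source may report more compounds than this note shows. Statements on the series, on what has been measured and on what is new or still open speak of the compounds shown alone.

In a functional assay on cells (T-cell line, Homo sapiens) for inhibition (a higher number here means a weaker inhibitor, a lower number a stronger inhibitor), compound 1 (`COc1ccc(CCCN2CCC(CCC(c3ccccc3)c3ccccc3)CC2)cc1`) gives 200 nM and compound 2 (`COc1ccccc1CCCN1CCC(COC(c2ccccc2)c2ccccc2)CC1`) gives 2400 nM as the higher of the two numbers, beyond the scatter. Compound 3 (`CCCN1CCC(COC(c2ccccc2)c2ccccc2)CC1`) differs from compound 2 by one change (hydrogen in place of 2-methoxyphenyl on a saturated chain carbon, three bonds along the chain from an amine nitrogen in a ring), with hydrogen in place of 2-methoxyphenyl on a saturated chain carbon, three bonds along the chain from an amine nitrogen in a ring. Within the data shown here, no measured pair shows this change, so the expectation rests on weak grounds, but a moderate rise in this assay is expected. The estimate is a step of a 4.2-fold higher number from compound 2 to compound 3 (0.62 log units; beyond the scatter) towards a weaker inhibitor. For compound 3 the estimated value is 10000 nM (range 3000 nM to 30000 nM).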

Compound 3, half-maximal inhibitory concentration: 17800 nM
Compound 3: middle estimate off by 1.8-fold (0.25 log units), on the low side; the measured number falls inside the stated range.
By their numbers in this assay, from the lowest: compound 1; then compound 2; then compound 3.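

In this assay, hydrogen in place of 2-methoxyphenyl on a saturated chain carbon, three bonds along the chain from an amine nitrogen in a ring, gives a 7.4-fold higher number from compound 2 to compound 3 (0.87 log units; beyond the scatter), so inhibition at this position depends on what this chain carries. Even so, compound 3 keeps a measurable value without the aromatic ring. Nothing at hand explains this step. From the compounds shown here alone, it remains open whether an unsubstituted phenyl or a pyridine ring would hold the inhibition of compound 2, and whether the same loss would occur on the core of compound 1.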